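The source may hold more compounds than are shown below. What is called first, only, known or untested is meant among the compounds shown, and "the series" means these compounds.

Among the measured compounds shown here, in an assay on isolated protein for inhibition of protein deacetylase HDAC6 (Homo sapiens) (on this read-out lower numbers stand for stronger inhibition and higher numbers for weaker inhibition), compound 2 `COc1ccc(C(=O)c2ccc3c(ccn3Cc3ccc(C(=O)NO)cc3)c2)cc1` gives 3.92 nM, the lowest of the three numbers so far. Compound 1 `O=C(NO)c1ccc(Cn2ccc3cc(C(=O)c4ccc(F)cc4)ccc32)cc1` gives 9.25 nM, and compound 3 `COc1ccc(C(=O)c2ccc3c(ccn3Cc3ccc(/C=C/C(=O)NO)cc3)c2)cc1` gives 108 nM. The step of a 2.4-fold lower number from compound 1 to compound 2 (0.37 log units; beyond the scatter) is modest, whereas the step of a 28-fold higher number from compound 2 to compound 3 (1.44 log units; beyond the scatter) is large, so compound 2 sits clearly apart from compound 3 and only modestly apart from compound 1.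

Compound 4 `COc1cccc(C(=O)c2ccc3c(ccn3Cc3ccc(C(=O)NO)cc3)c2)c1` differs from compound 2 by 3-methoxyphenyl in place of 4-methoxyphenyl on a carbonyl carbon. For the measured compounds named here, no measured step repeats this exact change. The step of a 2.4-fold lower number from compound 1 to compound 2 (0.37 log units; beyond the scatter) comes nearest, as it also exchanges the group carried by the same carbonyl carbon, and it was modest. The step of a 28-fold higher number from compound 2 to compound 3 (1.44 log units; beyond the scatter) concerns the hydroxycarbamoyl end of the molecule and carries no information about the methoxyphenyl group. The expectation for compound 4 is therefore a small shift, a 1.5-fold higher number from compound 2 to compound 4 (0.18 log units; within the scatter), toward a somewhat higher number than compound 2, possibly within the scatter. Compound 4 is estimated at 6 nM, with a range from 2.5 nM to 15 nM.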

Compound 4, half-maximal inhibitory concentration: 16.4 nM
For compound 4 the middle estimate is 2.7-fold (0.44 log units) below the measured one, outside the stated range (above it).
By their numbers in this assay, from the lowest: compound 2; then compounds 1 and 4 (each within the scatter of the next); then compound 3.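

In this assay, the group on the carbonyl carbon responds to where the methoxy stands, and not only to whether it is present: with the same atoms joined differently, 3-methoxyphenyl in place of 4-methoxyphenyl gives a 4.2-fold higher number from compound 2 to compound 4 (0.62 log units; beyond the scatter), a modest change. Set against the fluorinated compound, 3-methoxyphenyl in place of 4-fluorophenyl gives a 1.8-fold higher number from compound 1 to compound 4 (0.25 log units; within the scatter), so the two cannot be told apart in this assay, and among these compounds the lower number of compound 2 goes with 4-methoxyphenyl and not with a methoxy group as such. Nothing available explains why the place of the methoxy group on this ring changes the number.

Going by these compounds, it remains open whether an ethoxy group or a dimethylamino group in place of the methoxy of compound 2 would keep its low number. On these data alone, it also remains open whether 3-methoxyphenyl in place of 4-methoxyphenyl would shift the number by a similar amount in compound 3, which carries the 2-(hydroxycarbamoyl)ethenyl group.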